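This account rests on a few compounds, and the source may have more. Where it says the series, first, only, none or still open, it means among the compounds named here.

Compound 1, `CC(C)(CN)C(CN)C(=O)O`, in an assay for inhibition of Ornithine decarboxylase (Rattus norvegicus) (a lower number here means a stronger inhibitor, a higher number a weaker inhibitor), gives > 11000000 nM, which is a limit of the assay and not a number.
Compound 2, `CC(CN)(CCN)C(=O)O`, in this assay gives > 11000000 nM, likewise a limit and not a number.

Compound 2 therefore stands at the limit of > 11000000 nM in this assay, at which 2 of the 2 values shown sit, and so nothing separates it from compound 1 on the numbers shown; neither compound reached a measurable inhibition constant, and no step between measured compounds can be drawn. The unmeasured compound 3, `CC(C)(CN)CCN`, differs from compound 2 by methyl in place of carboxy on a saturated chain carbon bound to three saturated chain carbons. Going by the values given here, because no measured step exists, the size of the change cannot be read from a comparable pair. The account expects that compound 3 may at most move modestly from the limit at which compound 2 sits, and that a limit is again the likelier outcome. Compound 3 is expected to give 5000000 nM, with a range from 500000 nM to 20000000 nM. That estimate means an expected step of an at least 2.2-fold lower number from compound 2 to compound 3 (0.34 log units; beyond the scatter).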

Compound 3, inhibition constant: > 10000000 nM
Compound 3: no number, only a limit (the forecaster's own chance of this, stated with the estimate: 60%); at least 2.0-fold (0.30 log units) between middle value and limit.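

No step can be read from compound 1 or from compound 2 to compound 3: all three results are limits of the assay and not numbers. The compounds shown leave open whether methyl in place of carboxy changes the inhibition constant in this assay at all.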